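From 4-methoxyphenyl to 2-chlorophenyl in compound 3

The source may report more compounds than this note shows. Statements on the series, on what has been measured and on what is new or still open speak of the compounds shown alone.

In a functional assay on A2780 cells (Homo sapiens) for antiproliferative activity, read by MTT assay, with a stated time of 72 h (on this read-out lower numbers stand for stronger inhibition and higher numbers for weaker inhibition), compound 3 `COc1ccc(C2CC(c3ccc(F)cc3)=NN2C(=O)c2cc3ccccc3o2)cc1` gives 23 ug/mL, within the scatter of compound 2 `O=C(c1cc2ccccc2o1)N1N=C(c2ccc(F)cc2)CC1c1ccccc1` at 11.8 ug/mL. Compound 1 `O=C(c1cc2ccccc2o1)N1N=C(c2ccccc2)CC1c1ccccc1Cl` gives 6.22 ug/mL, a number lower than that of compound 3 by more than the scatter. Compound 4 `O=C(c1cc2ccccc2o1)N1N=C(c2ccc(F)cc2)CC1c1ccccc1Cl` has 2-chlorophenyl in place of 4-methoxyphenyl on a saturated ring carbon. Within the data shown here, the one measured single change, a 1.9-fold higher number from compound 2 to compound 3 (0.29 log units; within the scatter), offers little guidance. The better guide is compound 1 at 6.22 ug/mL, which shares the 2-chlorophenyl with compound 4 but has no 4-fluorophenyl. On that basis, a 3.1-fold lower number from compound 3 to compound 4 (0.49 log units; beyond the scatter) is expected in this assay. For compound 4 the estimated value is 7.5 ug/mL, with an expected range of 3.5 ug/mL to 16 ug/mL.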

Compound 4, half-maximal inhibitory concentration: 45.2 ug/mL
Estimate against measurement, compound 4: 6.0-fold (0.78 log units) below, and the stated range ends below it.
By their numbers in this assay, from the lowest: compounds 1, 2, 3 and 4 (each within the scatter of the next, the first and the last beyond it).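

In this assay, 2-chlorophenyl on the saturated ring carbon does not bring the stronger inhibition that compound 1 suggested: a 2.0-fold higher number from compound 3 to compound 4 (0.29 log units; within the scatter) separates it from 4-methoxyphenyl, while a 3.8-fold higher number from compound 2 to compound 4 (0.58 log units; beyond the scatter) shows that chloro in place of hydrogen raises the number. The fluoro also matters, with a 7.3-fold higher number from compound 1 to compound 4 (0.86 log units; beyond the scatter), so the low number of compound 1 does not carry over to the fluorinated series. No measurement shown here explains these steps. As far as these compounds go, the effect of chloro without the fluoro remains open, since the shared core with neither group is absent from these compounds. From the compounds shown here alone, how an amine or a carboxylic acid on this aromatic ring would behave also remains open.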